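A chloro-to-methyl swap at the assay limit

The compounds below may be only part of what the source reports. "The series", "measured", "known", "first", "only" and "open" are said of these compounds alone.

In a functional assay on A549 cells (Homo sapiens) for cytotoxicity, read by MTT assay, with a stated time of 72 h (on this read-out higher numbers stand for weaker inhibition and lower numbers for stronger inhibition), the measured compounds stand as follows:
- compound 1 `CNC(=O)c1cc(Oc2ccc(NC(=O)c3cc(-c4ccc(Cl)cc4)ncn3)cc2F)ccn1` gives > 100000 nM as a limit
- compound 2 `CNC(=O)c1cc(Oc2ccc(NC(=O)c3nccc(-c4ccc([N+](=O)[O-])cc4)n3)cc2)ccn1` gives > 100000 nM as a limit
- compound 3 `CNC(=O)c1cc(Oc2ccc(NC(=O)c3cc(-c4ccc(Cl)cc4)ncn3)cc2)ccn1` gives > 100000 nM as a limit

None of these three results is a number, and compound 1 sits with the others at the limit of > 100000 nM in this assay, at which 3 of the 3 values shown sit, and has no rank of its own. Compound 4 `CNC(=O)c1cc(Oc2ccc(NC(=O)c3cc(-c4ccc(C)cc4)ncn3)cc2F)ccn1` keeps the core of compound 1 and has methyl in place of chloro on an aromatic carbon, para to a large group (methyl in place of chloro on an aromatic carbon), turning 4-chlorophenyl into 4-methylphenyl. Among the measured compounds shown here, no measured step touches that group. The nearest one, a step that the two limits leave unreadable from compound 1 to compound 3 with hydrogen in place of fluoro on an aromatic carbon, is a different change and gives no size to carry over. The expectation therefore rests on compound 1, which gives > 100000 nM as a limit of the assay. The expected step of a number no higher from compound 1 to compound 4 (the limit leaves the size open) is estimated to stay within the scatter, with no direction favoured. Compound 4 is estimated at 100000 nM in this assay with an expected range from 40000 nM to 150000 nM and will probably be reported as a limit again.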

Compound 4, half-maximal inhibitory concentration: 13200 nM
For compound 4 the middle estimate is 7.6-fold (0.88 log units) above the measured one; measured number outside the range, below it.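

Methyl in place of chloro on the aromatic carbon gives an at least 7.5-fold lower number from compound 1 to compound 4 (0.87 log units; beyond the scatter), so a change at this position can move the read-out in this assay, which the earlier compounds could not show. As far as these compounds go, compound 1 gives > 100000 nM, which is a limit and not a number, and the true size of the step therefore remains unknown. Compound 4 is the only compound shown with a number rather than a limit: the limit of > 100000 nM in this assay, at which 3 of the 4 values shown sit.

From the compounds shown here alone, the step for hydrogen in place of fluoro cannot be read, so what the fluoro contributes remains unknown, and the same holds for that change when methyl is present. Going by these compounds, it also remains open whether an ethyl, a methoxy or an amine on the same aromatic carbon would lower the number further or return it to the limit.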